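Variation of the ring amine nitrogen substituent in compound 1

The compounds below may be only part of what the source reports. "The series", "measured", "known", "first", "only" and "open" are said of these compounds alone.

compound 1 `CCCCNc1nc(N)nc2c1CN(C)CC2`: 0.03 uM
compound 2 `CCCCNc1nc(N)nc2c1CN(Cc1cccc3ccccc13)CC2`: 0.43 uM
compound 3 `CCCCNc1nc(N)nc2c1CN(Cc1c[nH]c3ccccc13)CC2`: 0.22 uM

In an assay on HEK293 cells for agonist activity at Toll-like receptor 8 (Homo sapiens), read by a luciferase reporter, with a stated time of 6 h (a higher number here means that more compound is needed for the effect, a lower number that less compound is needed), compound 1 gives 0.03 uM, the lowest of the three numbers. Compound 3 stands higher at 0.22 uM, beyond the scatter, and compound 2 higher still at 0.43 uM. Both measured replacements of the methyl on the ring amine nitrogen thus raise the number.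

Compound 4 `CCCCNc1nc(N)nc2c1CN(C(=O)c1csc(N)n1)CC2` differs from compound 1 by (2-amino-1,3-thiazol-4-yl)carbonyl in place of methyl on an amine nitrogen in a ring. The entering group is larger than methyl, as were those in compounds 2 and 3, and no measured case shows such a replacement leaving the number unchanged. The step from compound 1 to compound 4 is expected to be a rise beyond the scatter, a 10-fold higher number from compound 1 to compound 4 (1.00 log units; beyond the scatter). For compound 4 the estimate is 0.3 uM, expected between 0.06 uM and 1.5 uM.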

Compound 4, minimum effective concentration: 6.9 uM
Estimate against measurement, compound 4: 23-fold (1.36 log units) below; measured number outside the range, above it.
By their numbers in this assay, from the lowest: compound 1; then compounds 3 and 2 (each within the scatter of the next); then compound 4.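

In this assay, (2-amino-1,3-thiazol-4-yl)carbonyl in place of methyl on the ring amine nitrogen gives a 230-fold higher number from compound 1 to compound 4 (2.36 log units; beyond the scatter), so this position can lose far more than compounds 2 and 3 showed. Among these compounds, compound 4 is also the only compound here with a carbonyl on that nitrogen. Nothing available accounts for the size of this step.

As far as these compounds go, whether the carbonyl or the 2-amino-1,3-thiazol-4-yl part carries the rise stays open. An acetyl group on that nitrogen would separate the two, and an ethyl group would test a smaller change from methyl.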